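The compounds below may be only part of what the source reports. "The series", "measured", "known", "first", "only" and "open" are said of these compounds alone.

Notes on the series, step from compound 1 to compound 3.

Compound 1 `O=C1O[C@H]([C@@H](O)Cn2cc(-c3ccc(Br)cc3)nn2)C(OCc2ccccc2)=C1OCc1ccccc1` carries a 4-bromophenyl group on the five-membered aromatic ring with 3 nitrogen. Among the measured compounds shown here, in a functional assay on HepG2 cells (Homo sapiens) for antiproliferative activity, read by MTT assay, with a stated time of 72 h (on this read-out higher numbers stand for weaker inhibition and lower numbers for stronger inhibition), compound 1 gives 5070 nM, the lowest of the two numbers measured so far. Compound 2 `O=C1O[C@H]([C@@H](O)Cn2cc(-c3cccc(O)c3)nn2)C(OCc2ccccc2)=C1OCc1ccccc1` differs from it only in that 3-hydroxyphenyl replaces 4-bromophenyl on an aromatic carbon; in this assay compound 2 gives 62700 nM, and the step of a 12-fold higher number from compound 1 to compound 2 (1.09 log units; beyond the scatter) is large.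

Compound 3 `C[Si](C)(C)c1cn(C[C@H](O)[C@H]2OC(=O)C(OCc3ccccc3)=C2OCc2ccccc2)nn1` is not yet measured. Its change from compound 1 is a group of 4 heavy atoms (3 carbon, 1 silicon; no ring) in place of a group of 7 heavy atoms (6 carbon, 1 bromine; one six-membered aromatic ring of carbon only), on an aromatic carbon. For the measured compounds named here, the one measured step bears on this only loosely: it shows that altering the group on this aromatic carbon, while keeping a six-membered ring, already moved the number well beyond the scatter, as the step from compound 1 to compound 2 records. Removing the ring altogether is a further departure, so a step in the same direction, toward a higher number, is expected, though of uncertain size; the expected step is a 3.9-fold higher number from compound 1 to compound 3 (0.60 log units; beyond the scatter). For compound 3 the estimate in this assay is 20000 nM, within a range from 5000 nM to 80000 nM.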

Compound 3, half-maximal inhibitory concentration: 24100 nM
Compound 3: the middle estimate sits 1.2-fold (0.08 log units) below what was measured, within the range that was stated.
By their numbers in this assay, from the lowest: compound 1; then compound 3; then compound 2.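

In this assay, the group of 4 heavy atoms (3 carbon, 1 silicon; no ring) on this aromatic carbon gives a 4.8-fold higher number from compound 1 to compound 3 (0.68 log units; beyond the scatter), and the same group in place of 3-hydroxyphenyl gives a 2.6-fold lower number from compound 2 to compound 3 (0.42 log units; beyond the scatter), so the ringless group ranks inside the span set by the two phenyl groups. The presence of a six-membered aromatic ring at this position therefore does not by itself order the three numbers: compound 2 keeps such a ring and has a higher number than compound 3, while compound 1 keeps one and has a lower number. Nothing available accounts for this order in terms of any measured property of the groups.

The compounds shown leave open whether the gap between compound 1 and compound 2 follows from the bromine, the hydroxyl or their different places on the phenyl ring, which plain phenyl, 4-hydroxyphenyl and 3-bromophenyl groups would help to separate. They also leave open how this position responds to other ringless groups, such as a tert-butyl group, a longer alkyl chain, an amine or a carboxylic acid.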